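Chloro to 3-Hydroxypropyl: an Expected Loss of Potency

This account rests on a few compounds, and the source may have more. Where it says the series, first, only, none or still open, it means among the compounds named here.

Compound 1 `Cc1cccc(Nc2nc(-c3ccncc3Cl)cs2)c1` stands alone with a single number in a functional assay on RCC4 cells (Homo sapiens) for inhibition, read by XTT assay, with a stated time of 4 days (a higher number here means a weaker inhibitor, a lower number a stronger inhibitor), where compound 1 gives 2950 nM. Compound 2 `Cc1cccc(Nc2nc(-c3ccncc3-c3ccccc3)cs2)c1` gives 11600 nM; 11700 nM (2 entries) in this assay, a higher number than compound 1. Compound 3 `Cc1cccc(Nc2nc(-c3ccncc3CCCO)cs2)c1` has not yet been measured; it differs from compound 1 by 3-hydroxypropyl in place of chloro on an aromatic carbon. For the measured compounds named here, no step between measured compounds is available, so the expectation rests only on these two values and the change itself. Compound 3 is expected to give 6000 nM, in a range from 2000 nM to 18000 nM. The step of a 2.0-fold higher number from compound 1 to compound 3 (0.31 log units; beyond the scatter) is estimated as a moderate weakening, beyond the scatter.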

Compound 3, half-maximal inhibitory concentration: 6920 nM
Beside the measured number, compound 3's estimate is 1.2-fold (0.06 log units) below it; the range from low to high includes it.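

In this assay, the step of a 2.3-fold higher number from compound 1 to compound 3 (0.37 log units; beyond the scatter) shows that this position, ortho to a large group and two atoms from the ring nitrogen, can carry a 3-hydroxypropyl chain, with its hydrogen-bond donor and acceptor, at a modest cost. Compound 3 at 6920 nM also gives a lower number than compound 2 at 11600 nM; 11700 nM (2 entries), so a larger replacement for chloro need not match the number of compound 2. Nothing given here explains the change in potency. From the compounds shown here alone, what a plain propyl chain, an amine in place of the hydroxyl or a longer chain would give at this position remains open.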